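Carbonyl substituent variation in the anilinopyrimidine series

The source may report more compounds than this note shows. Statements on the series, on what has been measured and on what is new or still open speak of the compounds shown alone.

Three compounds share one core and differ only at a carbonyl carbon that sits on an aromatic carbon. Compound 1 `COC(=O)c1cccn1-c1ccc(Nc2ncc(Cl)c(Nc3ccccc3NS(C)(=O)=O)n2)c(OC)c1` carries a methyl ester there; in a functional assay on NCI-H2228 cells (Homo sapiens) for antiproliferative activity, read by MTT assay, with a stated time of 72 h (a lower number here means a stronger inhibitor, a higher number a weaker inhibitor), compound 1 gives 950 nM. Compound 2 `COc1cc(-n2cccc2C(=O)O)ccc1Nc1ncc(Cl)c(Nc2ccccc2NS(C)(=O)=O)n1` carries the free acid; in this assay compound 2 gives 640 nM. Compound 3 `COc1cc(-n2cccc2C(=O)N2CCCCC2)ccc1Nc1ncc(Cl)c(Nc2ccccc2NS(C)(=O)=O)n1` carries a piperidin-1-yl on the carbonyl carbon; in this assay compound 3 gives 630 nM. Compound 2 stands second highest of the three numbers, with compound 3 nearest and compound 1 furthest, yet every step among them is within the scatter: a 1.5-fold lower number from compound 1 to compound 2 (0.17 log units; within the scatter), a 1.5-fold lower number from compound 1 to compound 3 (0.18 log units; within the scatter), a 1.0-fold lower number from compound 2 to compound 3 (0.01 log units; within the scatter).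

Compound 4 `CCN1CCN(C(=O)c2cccn2-c2ccc(Nc3ncc(Cl)c(Nc4ccccc4NS(C)(=O)=O)n3)c(OC)c2)CC1` has not been measured in this assay. Against compound 2 the change is 4-ethylpiperazin-1-yl in place of hydroxy on a carbonyl carbon. Going by the values given here, the step from compound 2 to compound 3 is the closest precedent, a ring nitrogen replacing hydroxy on the same carbonyl carbon, and it moved the number by essentially nothing. The step from compound 1 to compound 3 likewise stayed within the scatter. Among the compounds with values here, no measured step in this set shows that the group on the carbonyl carbon shifts the number beyond the scatter, so compound 4 is expected to move by a 1.1-fold lower number from compound 2 to compound 4 (0.03 log units; within the scatter) at most. Compound 4 is therefore estimated at 600 nM, within a range of 300 nM to 1200 nM.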

Compound 4, half-maximal inhibitory concentration: 1130 nM
Estimate against measurement, compound 4: 1.9-fold (0.27 log units) below, and the stated range covers the measured number.
By their numbers in this assay, from the lowest: compounds 3, 2, 1 and 4 (each within the scatter of the next).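

In this assay, replacing hydroxy with 4-ethylpiperazin-1-yl on the carbonyl carbon gives a 1.8-fold higher number from compound 2 to compound 4 (0.25 log units; within the scatter) and thus stays within the scatter, which extends the earlier finding to a substituted ring with 2 hetero atoms. Exchanging piperidin-1-yl for the same group gives a 1.8-fold higher number from compound 3 to compound 4 (0.25 log units; within the scatter) and exchanging methoxy for it gives a 1.2-fold higher number from compound 1 to compound 4 (0.08 log units; within the scatter), so hydroxy, methoxy, piperidin-1-yl and 4-ethylpiperazin-1-yl on this carbonyl carbon remain indistinguishable in these measurements, and the added ring nitrogen with its ethyl group produces no step beyond the scatter. No accompanying measurement bears on these numbers, so nothing here accounts for them.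

Open-chain amides such as the dimethylamide, a primary amide, and piperazines bearing a longer chain or a free ring amine in place of the ethyl group lie outside the compounds shown. On these data alone, it also remains open whether any group on this carbonyl carbon, or a nitrile or an aminomethyl group in place of the whole carbonyl unit, would move the number beyond the scatter.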